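Methoxy in Place of Amino on the Fused Core

The source may hold more compounds than are shown below. What is called first, only, known or untested is meant among the compounds shown, and "the series" means these compounds.

Compound 2 `CCc1ccc(N(CC(C)C)S(=O)(=O)c2ccc3c(c2)C(N)CC(C2CCOCC2)O3)cc1` stands lowest of the three compounds measured in a physicochemical assay for lipophilicity, at pH 7.4 (a higher number here means a more lipophilic compound, a lower number a more polar compound), where compound 2 gives 3.08. Compound 1 `CCc1ccc(N(CC(C)C)S(=O)(=O)c2ccc(OCC3CCOCC3)c(CN)c2)cc1` gives 3.25 in this assay, a number within the scatter of compound 2. Compound 3 `CCc1ccc(N(CC(C)C)S(=O)(=O)c2ccc3c(c2)C(O)C[C@@H](C2CCOCC2)O3)cc1` gives 4.12, a number beyond the scatter and above compound 2. The unmeasured compound 4 `CCc1ccc(N(CC(C)C)S(=O)(=O)c2ccc3c(c2)C(OC)CC(C2CCOCC2)O3)cc1` differs from compound 2 in one place: methoxy in place of amino on a saturated ring carbon. Among the compounds with values here, no step between measured compounds covers this exchange. A rise beyond the scatter is expected for compound 4, estimated as a number 1.32 log units higher from compound 2 to compound 4 (beyond the scatter), because compound 3, which also lacks the amino group, gives 4.12 in this assay. Compound 4 is therefore expected at 4.4, within a range from 3.9 to 4.9.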

Compound 4, distribution coefficient: 4.69
Compound 4: middle estimate off by 0.29 log units, on the low side; low and high end bracket the measured number.
By their numbers in this assay, from the lowest: compounds 2 and 1 (each within the scatter of the next); then compound 3; then compound 4.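

In this assay, within the data shown here, methoxy in place of amino on the saturated ring carbon gives a number 1.61 log units higher from compound 2 to compound 4 (beyond the scatter) and is the first measured step at this position. The exchange is large, and it goes from amino, with 1 hydrogen-bond donor, to methoxy, with 0 hydrogen-bond donors, while each group has 1 hydrogen-bond acceptor. No evidence on the cause of this step is available here. From the compounds shown here alone, what stays open is where an ethoxy group or a methylamino group on the same carbon would fall in this assay.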